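Aryl Groups in Place of Bromo on a Shared Core

The source may report more compounds than this note shows. Statements on the series, on what has been measured and on what is new or still open speak of the compounds shown alone.

Of the compounds shown here, three built on one shared core have been tested in a functional assay on NCI/ADR-RES cells (Homo sapiens) for inhibition, read by sulforhodamine B assay, with a stated time of 48 h, tested at 10 uM; a lower number here means less inhibition, a higher number more inhibition at the concentration tested (going by the name of the read-out). Compound 1 `Brc1cn2ccnc2c(-c2ccc3ncn(C4CCCCC4)c3c2)n1` gives 8.82%. Compound 2 `CC(=O)c1ccc(-c2cn3ccnc3c(-c3ccc4ncn(C5CCCCC5)c4c3)n2)cc1` gives 4.17%. Compound 3 `Clc1ccc(-c2cn3ccnc3c(-c3ccc4ncn(C5CCCCC5)c4c3)n2)cc1` gives 11.1%. Compound 1 stands second highest of the three numbers; the nearest step is a number 2.3 percentage points higher from compound 1 to compound 3 (within the scatter) and the furthest is a number 4.7 percentage points lower from compound 1 to compound 2 (within the scatter), and the remaining step, a number 6.9 percentage points higher from compound 2 to compound 3 (within the scatter), also lies within the scatter, so none of the three is separated from another.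

Compound 4 `Brc1ccc(-c2cn3ccnc3c(-c3ccc4ncn(C5CCCCC5)c4c3)n2)cc1` has not yet been measured. It differs from compound 1 by 4-bromophenyl in place of bromo on an aromatic carbon. Among the compounds with values here, the steps that bear on this change are the two earlier replacements of bromo by a substituted phenyl, a number 4.7 percentage points lower from compound 1 to compound 2 (within the scatter) and a number 2.3 percentage points higher from compound 1 to compound 3 (within the scatter), neither of which reached beyond the scatter. Compound 4 is therefore expected to show no step beyond the scatter, with the estimated change being a number 1.2 percentage points higher from compound 1 to compound 4 (within the scatter). For compound 4 in this assay the estimate is 10%, expected to fall between 2% and 20%.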

Compound 4, a percentage reported as inhibition, at one concentration (the size of the read-out at that concentration, not a potency): 30.5%
The estimate for compound 4 lay 20.5 percentage points below the measured number; measured number outside the range, above it.
By their numbers in this assay, from the lowest: compounds 2, 1 and 3 (each within the scatter of the next); then compound 4.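

In this assay, this position on an aromatic carbon next to the ring nitrogen now shows a change beyond the scatter, as 4-bromophenyl in place of bromo gives a number 21.7 percentage points higher from compound 1 to compound 4 (beyond the scatter) for the first time among these replacements. A phenyl ring alone does not account for this pattern, since compounds 2 and 3 also carry one, yet bromo in place of chloro gives a number 19.4 percentage points higher from compound 3 to compound 4 (beyond the scatter) and bromo in place of acetyl gives a number 26.3 percentage points higher from compound 2 to compound 4 (beyond the scatter) on that ring. What the phenyl ring carries therefore matters here, and no measurement at hand explains why bromo stands apart from chloro and acetyl.

The compounds shown leave open how an amine, a carboxylic acid or a methoxy group on the phenyl ring would read in this assay. They also leave open whether iodo would follow bromo or fall back with chloro.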